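The source may report more compounds than this note shows. Statements on the series, on what has been measured and on what is new or still open speak of the compounds shown alone.

Measured compounds:
- compound 1 `CC(CC(C)(C)C)Oc1cccc2cccnc12`: > 2000 nM
- compound 2 `CC#CCCOc1cccc2ccc(N)nc12`: > 2000 nM
- compound 3 `CC(CC(C)(C)C)Oc1cccc2ccc(N3CCCCC3)nc12`: > 2000 nM

These were tested in an assay on cells with melanin-concentrating hormone receptor 1 (Homo sapiens) as the target, read by radioligand binding; on this read-out lower numbers stand for stronger inhibition and higher numbers for weaker inhibition. For compound 1 the value given is a limit of the assay, not a number. For compound 2 the value is likewise a limit. For compound 3 it is again a limit. For the measured compounds named here, the only change with measured values on both sides, a step that the two limits leave unreadable from compound 1 to compound 3, cannot be read either, since both ends sit at the limit; the limit of > 2000 nM in this assay, at which 3 of the 3 values shown sit, shows how little the numbers can tell here.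

The step considered now leads from compound 2 to the unmeasured compound 4 `CSCCOc1cccc2ccc(N)nc12`. The change is methylsulfanyl in place of prop-1-yn-1-yl on a saturated chain carbon, two bonds along the chain from an oxygen on an aromatic ring. Going by the values given here, no measured step covers this kind of exchange, so there is nothing to set a direction or size of the step in this assay. With all three measured compounds at the limit, compound 4 is expected to land near that limit as well. The step expected from this is a step that the limit leaves unreadable from compound 2 to compound 4. The estimate for compound 4 is therefore 4000 nM, between 1000 nM and 15000 nM.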

Compound 4, half-maximal inhibitory concentration: > 2000 nM
Compound 4 gave a limit, no number; the forecaster's own chance of this, stated with the estimate: 80%; the middle value lies beyond the limit too.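

For the compounds shown here, compound 2 and compound 4 each give only a limit, not a number, so no step between them can be read: the limit of > 2000 nM in this assay, at which 4 of the 4 values shown sit. The compounds shown leave open which change, if any, would give a measured number in this assay rather than a limit.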